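The compounds below may be only part of what the source reports. "The series", "measured", "known", "first", "only" and "open" are said of these compounds alone.

Series notes, antiproliferative work on a breast-cancer line.

Compound 1, `COc1ncc(-c2ccc3nc(NC(C)=O)nn3c2)cc1NS(=O)(=O)c1ccc(C)cc1`, is the reference point of the set. In a functional assay on MCF7 cells (Homo sapiens) for antiproliferative activity, read by MTT assay, with a stated time of 48 h (a higher number here means a weaker inhibitor, a lower number a stronger inhibitor), compound 1 gives 810 nM. Compound 2, `COc1ncc(-c2ccc3nc(N)nn3c2)cc1NS(=O)(=O)c1ccc(C)cc1`, keeps everything in compound 1 except for one change, (hydrogen in place of acetyl on a nitrogen on an aromatic ring). In this assay compound 2 gives 1550 nM. The step is a 1.9-fold higher number from compound 1 to compound 2 (0.28 log units; within the scatter), so removing the acetyl from the nitrogen on the aromatic ring has not moved the number outside ordinary repeat variation.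

Compound 3, `COc1ncc(-c2ccn3nc(NC(C)=O)nc3c2)cc1NS(=O)(=O)c1ccc(F)cc1`, carries the acetyl on the same kind of nitrogen but sits on a different core and has fluorine rather than methyl on the sulfonamide aryl ring; the difference between the two cores is not broken down here. In this assay compound 3 gives 1730 nM, which stands within the scatter of compound 2 and beyond it relative to compound 1.

Compound 4, `COc1ncc(-c2ccn3nc(N)nc3c2)cc1NS(=O)(=O)c1ccc(F)cc1`, is not yet measured. It relates to compound 3 as compound 2 relates to compound 1: the change is hydrogen in place of acetyl on a nitrogen on an aromatic ring, at a place described in identical words in both pairs, so it is taken as the same change. Going by the values given here, the expectation for the step in this assay rests on the single precedent, a 1.9-fold higher number from compound 1 to compound 2 (0.28 log units; within the scatter), and is set at a 1.7-fold higher number from compound 3 to compound 4 (0.24 log units; within the scatter). On that basis compound 4 is estimated at 3000 nM, with a plausible span from 1500 nM to 6500 nM. The span is wide because a 1.9-fold higher number from compound 1 to compound 2 (0.28 log units; within the scatter) was itself within the scatter.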

Compound 4, half-maximal inhibitory concentration: 920 nM
Beside the measured number, compound 4's estimate is 3.3-fold (0.51 log units) above it; measured number outside the range, below it.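

In this assay the change from acetamido to amino gives a 1.9-fold lower number from compound 3 to compound 4 (0.27 log units; within the scatter), a step that on its own stays within ordinary repeat variation. Set beside the earlier step, the change does not carry over as one fixed shift from one core to the other, since the two steps point in opposite directions and the gap between them exceeds the scatter: the same change on two cores in this assay, a 1.9-fold higher number (0.28 log units; within the scatter) from compound 1 to compound 2 and a 1.9-fold lower number (0.27 log units; within the scatter) from compound 3 to compound 4, 3.6-fold (0.56 log units) apart, beyond the scatter of two such steps This does not show what sets the gap, or that either step has a reliable direction: each step rests on a single pair, and the two pairs differ both in the core and in fluorine versus methyl on the sulfonamide aryl ring, so the gap cannot be assigned to the core alone.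

The compounds shown leave open whether the gap follows the core or the aryl substituent, a question that an acetamido and amino pair with methyl on the core of compound 3, or with fluorine on the core of compound 1, would address. Also open, going by these compounds, is how a propionyl or a methanesulfonyl group in place of acetyl on that nitrogen would read on either core.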